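The compounds below may be only part of what the source reports. "The series", "measured", "known", "first", "only" and "open" are said of these compounds alone.

Compound 2, `Cc1cc(C)cc(S(=O)(=O)c2c(C(=O)N[C@@H]3CCN(S(C)(=O)=O)C3)[nH]c3ccc(Cl)cc23)c1`, holds the only number shown in an ADME assay on MT4 cells (Homo sapiens) for cytotoxicity, read by MTT assay, with a stated time of 5 days; on this read-out lower numbers stand for higher toxicity in this test and higher numbers for lower toxicity in this test: compound 2 gives 24000 nM. Its neighbour compound 1, `Cc1cc(C)cc(S(=O)(=O)c2c(C(=O)N[C@@H]3CCN(Cc4ccccc4F)C3)[nH]c3ccc(Cl)cc23)c1`, reaches only a limit of this assay: compound 1 gives > 231000 nM. Among the measured compounds shown here, the single measured step, an at least 9.6-fold lower number from compound 1 to compound 2 (0.98 log units; beyond the scatter), therefore rests on the limit of > 231000 nM in this assay, at which 1 of the 2 values shown sits, and tells only that compound 2 lies at least that far below the limit.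

Compound 3, `CCS(=O)(=O)NC(=O)c1[nH]c2ccc(Cl)cc2c1S(=O)(=O)c1cc(C)cc(C)c1`, is the next member. Its difference from compound 2 is ethylsulfonyl in place of 1-(methylsulfonyl)pyrrolidin-3-yl on an amide-type nitrogen. For the measured compounds named here, this change sits on the amide-type nitrogen, not on the amine nitrogen in the ring where the measured step acted, and the whole five-membered ring leaves; no measured pair speaks to that place. Going by the values given here, the one step available, from a benzyl to a sulfonyl on the ring nitrogen, was at least modest, but it does not carry over to an ethylsulfonyl on the amide-type nitrogen.

Among the compounds with values here, with no direct precedent, the number for compound 3 is expected to stay near that of compound 2, with the step of a 2.1-fold higher number from compound 2 to compound 3 (0.32 log units; beyond the scatter) likely within or only just beyond the scatter. Compound 3 is estimated at 50000 nM, between 15000 nM and 200000 nM.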

Compound 3, half-maximal cytotoxic concentration: > 283000 nM
Compound 3: a limit, no number; the forecaster's own chance of this, stated with the estimate: 25%; middle value at least 5.6-fold (0.75 log units) away from the limit.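

Replacing 1-(methylsulfonyl)pyrrolidin-3-yl with ethylsulfonyl on the amide-type nitrogen gives an at least 11-fold higher number from compound 2 to compound 3 (1.07 log units; beyond the scatter) in this assay, so this place can also move the read-out, which the earlier step on the amine nitrogen in the ring could not show. Among the compounds shown here, compound 3 reaches only a limit of this assay, so the step has a smallest size and no exact size, and its reading rests on that limit: the limit of > 283000 nM in this assay, at which 1 of the 3 values shown sits. Compound 2 is now the only one of the three compounds with a number, and its steps from both neighbours are printed as beyond the scatter, with the number of compound 2 the lower in each.

This one change removes the ring and also puts a sulfonyl directly on the amide-type nitrogen, and the compounds shown do not separate these two parts of the change. On these data alone, it remains open how a simple pyrrolidin-3-yl with a free ring amine, or a longer chain such as butylsulfonyl on the amide-type nitrogen, would read in this assay.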